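A larger five-membered ring group on compound 3

The source may hold more compounds than are shown below. What is called first, only, known or untested is meant among the compounds shown, and "the series" means these compounds.

Measured in a functional assay for inhibition, with Homo sapiens as the target; a lower number here means a stronger inhibitor, a higher number a weaker inhibitor:
- Compound 1 `Cn1nnnc1-c1cc(-c2ccccc2)c2ccc(OCc3cccc(C4(O)CCOCC4)c3)cc2c1`: > 67 nM (a limit, not a number)
- Compound 2 `N#Cc1cc(-c2ccoc2)c2ccc(OCc3cccc(C4(O)CCOCC4)c3)cc2c1`: 2 nM
- Compound 3 `OC1(c2cccc(COc3ccc4c(-c5ccoc5)cc(C5=NCCO5)cc4c3)c2)CCOCC1`: 3 nM

In this assay compound 3 gives 3 nM and compound 2 gives 2 nM, two values within the scatter of each other. Compound 1 offers only a limit and so gives no number to compare.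

The change to compound 4 `CC1(C)COC(c2cc(-c3ccoc3)c3ccc(OCc4cccc(C5(O)CCOCC5)c4)cc3c2)=N1` is a group of 7 heavy atoms (5 carbon, 1 nitrogen, 1 oxygen; one five-membered non-aromatic ring with 2 hetero atoms) in place of a group of 5 heavy atoms (3 carbon, 1 nitrogen, 1 oxygen; one five-membered non-aromatic ring with 2 hetero atoms), on an aromatic carbon. It sits on an aromatic carbon of a six-membered aromatic ring of carbon only, meta to a furan-3-yl group.

For the measured compounds named here, only one measured step bears on this place: a 1.5-fold higher number from compound 2 to compound 3 (0.18 log units; within the scatter). That exchange, of a group of 2 heavy atoms for a group of 5, left the value within the scatter, so no step beyond the scatter is expected here, though that single step is thin support. The expected step is a 1.3-fold higher number from compound 3 to compound 4 (0.12 log units; within the scatter). The estimate for compound 4 is 4 nM, with an expected range from 1.5 nM to 12 nM.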

Compound 4, half-maximal inhibitory concentration: 17 nM
For compound 4 the middle estimate is 4.3-fold (0.63 log units) below the measured one; the measured number lies above the stated range.
By their numbers in this assay, from the lowest: compounds 2 and 3 (each within the scatter of the next); then compound 4. At a limit, above all of these: compound 1.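

In this assay this position turns out not to accept every group equally: the exchange of the nitrile for the group of 5 heavy atoms had stayed within the scatter, yet the larger group of 7 heavy atoms gives a 5.7-fold higher number from compound 3 to compound 4 (0.75 log units; beyond the scatter). Set against the nitrile, the same group gives an 8.5-fold higher number from compound 2 to compound 4 (0.93 log units; beyond the scatter), so the tolerance seen with compound 3 does not extend to compound 4, although both carry a five-membered non-aromatic ring with 2 hetero atoms. Nothing available here bears on the cause of this rise.

The compounds shown leave open whether a single methyl group on that ring would already raise the number. They also leave open how an amine or a carboxylic acid at this place would compare with compound 3 at 3 nM.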